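Replacing 1H-benzimidazol-6-yl with 2-hydroxyethyl on the amide

This account rests on a few compounds, and the source may have more. Where it says the series, first, only, none or still open, it means among the compounds named here.

Of the compounds shown here, three sharing one core have been tested in a functional assay on CLL cells (Homo sapiens) for cytotoxicity, read by MTT assay, with a stated time of 48 h (on this read-out higher numbers stand for an effect only at larger amounts of compound and lower numbers for an effect already at smaller amounts), so far. Compound 1 (`C=C(CC)C(=O)c1ccc(OCC(=O)Nc2ccc(C(=O)O)cn2)c(Cl)c1Cl`) gives 14900 nM in this test. Compound 3 (`C=C(CC)C(=O)c1ccc(OCC(=O)Nc2ccc3c(c2)C(O)N=NC3O)c(Cl)c1Cl`) gives 8500 nM in the same test. Compound 2 (`C=C(CC)C(=O)c1ccc(OCC(=O)Nc2ccc3nc[nH]c3c2)c(Cl)c1Cl`) gives 3200 nM as the lowest number of the three. Compound 4 (`C=C(CC)C(=O)c1ccc(OCC(=O)NCCO)c(Cl)c1Cl`) has 2-hydroxyethyl in place of 1H-benzimidazol-6-yl on an amide-type nitrogen. Going by the values given here, the one measured step at this place is modest and reads a 4.7-fold lower number from compound 1 to compound 2 (0.67 log units; beyond the scatter) in full. Among the compounds with values here, no measured compound has a group without a ring there, so any forecast is uncertain. Starting from the lowest number, a move upward of similar size is expected, namely a 2.8-fold higher number from compound 2 to compound 4 (0.45 log units; beyond the scatter) as an estimate. In this assay the estimate for compound 4 is 9000 nM and the expected range runs from 3000 nM to 27000 nM overall.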

Compound 4, half-maximal effective concentration: > 25000 nM
Compound 4 ended at the assay's limit; the forecaster's own chance of this, stated with the estimate: 10%; middle value at least 2.7-fold (0.44 log units) away from the limit.
By their numbers in this assay, from the lowest: compound 2; then compounds 3 and 1 (each within the scatter of the next). At a limit, above all of these: compound 4.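

Going by these compounds alone, at the amide-type nitrogen, 2-hydroxyethyl is the first group without a ring, and in this assay replacing 1H-benzimidazol-6-yl with it brings an at least 7.8-fold higher number from compound 2 to compound 4 (0.89 log units; beyond the scatter). Replacing 5-carboxypyridin-2-yl with it brings an at least 1.6-fold higher number from compound 1 to compound 4 (0.22 log units; that floor lies within the scatter), so compound 4 cannot be clearly separated from compound 1. Compound 4 gives a limit of the assay, not a number: the limit of > 25000 nM in this assay, at which 1 of the 4 values shown sits.

From the compounds shown here alone, it remains open whether a longer chain or a chain ending in an amine would behave like 2-hydroxyethyl. A plain benzene ring at this nitrogen would help show how much the ring itself matters.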